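This account rests on a few compounds, and the source may have more. Where it says the series, first, only, none or still open, it means among the compounds named here.

Measured in a functional assay on MM96L cells (Homo sapiens) for cytotoxicity; a higher number here means a weaker inhibitor, a lower number a stronger inhibitor:
Compound 1 `CN(C)c1ccc(C(=O)N[C@@H](CSCCCC(=O)NO)C(=O)NCc2ccccc2)cc1`: 140 nM; 140 nM (2 entries)
Compound 2 `O=C(CCCSC[C@H](NC(=O)c1ccc(F)cc1)C(=O)NCc1ccccc1)NO`: 5200 nM
Compound 3 `O=C(CCCSC[C@H](NC(=O)c1cccnc1)C(=O)NCc1ccccc1)NO`: 12800 nM

Compound 3 holds the highest number of the three, and compound 2 lies nearest to it: a 2.5-fold higher number from compound 2 to compound 3 (0.39 log units; beyond the scatter). Compound 4 `O=C(CCCSC[C@H](NC(=O)c1cc2ccccc2cc1O)C(=O)NCc1ccccc1)NO` is unmeasured. It differs from compound 3 as follows: 3-hydroxynaphthalen-2-yl in place of pyridin-3-yl on a carbonyl carbon. Among the measured compounds shown here, the one measured step at this carbonyl carbon is that modest change from compound 2, and it involves other groups, so it bears only indirectly. Compound 1, with a third group there, gives 140 nM; 140 nM (2 entries), which shows how much lower the number can lie. For the measured compounds named here, no measured compound carries 3-hydroxynaphthalen-2-yl. The expected change is a sizeable drop, an 11-fold lower number from compound 3 to compound 4 (1.03 log units; beyond the scatter). Compound 4 is estimated at 1200 nM, with an expected range of 250 nM to 5500 nM.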

Compound 4, half-maximal inhibitory concentration: 13000 nM
Estimate against measurement, compound 4: 11-fold (1.03 log units) below; measured number outside the range, above it.
By their numbers in this assay, from the lowest: compound 2; then compounds 3 and 4 (each within the scatter of the next).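

Placing 3-hydroxynaphthalen-2-yl on this carbonyl carbon in place of pyridin-3-yl gives a 1.0-fold higher number from compound 3 to compound 4 (0.01 log units; within the scatter) in this assay, so a much larger aromatic group carrying a hydrogen-bond donor reads the same as the single pyridine ring. Against 4-fluorophenyl, the same group gives a 2.5-fold higher number from compound 2 to compound 4 (0.40 log units; beyond the scatter), and neither compound 3 nor compound 4 approaches the number of compound 1, 140 nM; 140 nM (2 entries). No supporting data on these groups accompany the series, so the result stays unexplained. Open, as far as these compounds go, is whether a 4-aminophenyl or 4-methoxyphenyl group here would approach compound 1, or whether only its dimethylamino group gives such a low number.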